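The source may report more compounds than this note shows. Statements on the series, on what has been measured and on what is new or still open speak of the compounds shown alone.

Two members of the series have been run in a functional assay on HT-29 cells (Homo sapiens) for inhibition, read by flow cytometry, tested at 10 uM; on this read-out higher numbers stand for more inhibition at the one concentration tested (going by the name of the read-out) and lower numbers for less inhibition. Compound 1 `CCOc1ccc(C(=O)CSc2nc3ccccc3[nH]2)cc1` gives 55.2% in this assay, the highest of the two numbers shown, and compound 2 `COc1ccccc1C(=O)CSc1nc2ccccc2[nH]1` gives 34.9%, a gap that lies beyond the scatter. Compound 3 `O=C(CSc1nc2ccccc2[nH]1)c1ccc(F)cc1` has not yet been measured in this assay. It differs from compound 1 in one place: fluoro in place of ethoxy on an aromatic carbon. Within the data shown here, no step between measured compounds covers this change, so its size is open. A moderate fall is expected, the step from compound 1 to compound 3 being estimated at a number 15.2 percentage points lower from compound 1 to compound 3 (beyond the scatter). Compound 3 is estimated at 40% in this assay, expected to fall between 20% and 60%.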

Compound 3, a percentage reported as inhibition, at one concentration (the size of the read-out at that concentration, not a potency): "not active" (no number reported)
No number was reported for compound 3; there is nothing to compare the estimate with.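

Among these compounds, compound 3 carries no number in this assay, so no step from compound 1 to compound 3 can be read. No evidence bears on this result. As far as these compounds go, the size of the change from ethoxy to fluoro remains open.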